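Ortho-substituted phenyl triazines against murine dihydrofolate reductase

The source may report more compounds than this note shows. Statements on the series, on what has been measured and on what is new or still open speak of the compounds shown alone.

Measured compounds:
compound 1 `CC1(C)N=C(N)N=C(N)N1c1ccccc1I`: 2.49
compound 2 `CC1(C)N=C(N)N=C(N)N1c1ccccc1S`: 6.86
compound 3 `CC1(C)N=C(N)N=C(N)N1c1ccccc1C(F)(F)F`: 3.03

In an assay on isolated protein for inhibition of Dihydrofolate reductase (Mus musculus), at pH 7.20 (on this read-out lower numbers stand for lower potency and higher numbers for higher potency (the scale is a negative logarithm)), compound 3 stands second highest of the three numbers; its nearest neighbour is compound 1, and the step of a number 0.54 log units higher from compound 1 to compound 3 (beyond the scatter) is beyond the scatter but modest, while the step of a number 3.83 log units lower from compound 2 to compound 3 (beyond the scatter) is large. Compound 4 `CCc1ccccc1N1C(N)=NC(N)=NC1(C)C` is unmeasured and differs from compound 3 as follows: ethyl in place of trifluoromethyl on an aromatic carbon. The step from iodo to trifluoromethyl, a number 0.54 log units higher from compound 1 to compound 3 (beyond the scatter), shows that swapping one neutral group at this position for another moves this assay only modestly; the sulfanyl case, compound 2, is the sole large departure. Ethyl is expected to behave like the other neutral groups, so the step of a number 0.07 log units higher from compound 3 to compound 4 (within the scatter) is expected to lie within the scatter. Compound 4 is estimated at 3.1, within 2.3 to 4.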

Compound 4, logarithm of the reciprocal of the active concentration, log(1/C): 3.38
Beside the measured number, compound 4's estimate is 0.28 log units below it; low and high end bracket the measured number.
By their numbers in this assay, from the lowest: compound 1; then compound 3; then compound 4; then compound 2.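

In this assay, ethyl in place of trifluoromethyl gives a number 0.35 log units higher from compound 3 to compound 4 (beyond the scatter), so a group of carbon only at this position lands clear of the scatter, though the step is modest. The gap to sulfanyl stays large at a number 3.48 log units lower from compound 2 to compound 4 (beyond the scatter), while a number 0.89 log units higher from compound 1 to compound 4 (beyond the scatter) is also modest, so compound 2 remains the sole large departure among the four. On these data alone, whether that sulfanyl gain is particular to sulfanyl or shared by a hydroxyl or an amine at this position stays open. Nothing available explains these steps.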